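The source may hold more compounds than are shown below. What is called first, only, known or untested is meant among the compounds shown, and "the series" means these compounds.

Measured compounds in an assay on CHO cells for displacement of a labelled ligand from Substance-P receptor (Homo sapiens); on this read-out higher numbers stand for weaker inhibition and lower numbers for stronger inhibition:
- compound 1 `C[C@@H](O[C@H]1CN2C(=O)C=C(c3ccc(NS(C)(=O)=O)cc3)CC2[C@@H]1c1ccc(F)cc1)c1cc(C(F)(F)F)cc(C(F)(F)F)c1` gives 1 nM
- compound 2 `C[C@@H](O[C@H]1CN2C(=O)C=C(c3ccncc3)CC2[C@@H]1c1ccc(F)cc1)c1cc(C(F)(F)F)cc(C(F)(F)F)c1` gives 0.14 nM
- compound 3 `COc1cc(C2=CC(=O)N3C[C@H](O[C@H](C)c4cc(C(F)(F)F)cc(C(F)(F)F)c4)[C@@H](c4ccc(F)cc4)C3C2)ccn1` gives 1.1 nM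

Compound 3 holds the highest of the three numbers in this assay, though its nearest neighbour is compound 1, which lies within the scatter of it (a 1.1-fold higher number from compound 1 to compound 3 (0.04 log units; within the scatter)). Against compound 2 the gap is real: a 7.9-fold higher number from compound 2 to compound 3 (0.90 log units; beyond the scatter).

Compound 4 `C[C@@H](O[C@H]1CN2C(=O)C=C(C3CCOCC3)CC2[C@@H]1c1ccc(F)cc1)c1cc(C(F)(F)F)cc(C(F)(F)F)c1` is the next step from compound 3: oxan-4-yl in place of 2-methoxypyridin-4-yl on a double-bonded ring carbon. Among the compounds with values here, none of the measured steps is of this kind. Two steps swap one aromatic group for another on the same double-bonded ring carbon (a 7.1-fold lower number from compound 1 to compound 2 (0.85 log units; beyond the scatter); a 1.1-fold higher number from compound 1 to compound 3 (0.04 log units; within the scatter)), and the third adds a methoxy to an aromatic carbon (a 7.9-fold higher number from compound 2 to compound 3 (0.90 log units; beyond the scatter)). None replaces the aromatic ring itself with a non-aromatic one, so the data give no direct guide, only the sign that this position tolerates changes of substituent with modest shifts in the measured number.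

On that basis a modest weakening in this assay is expected for compound 4, with wide uncertainty: a 3.6-fold higher number from compound 3 to compound 4 (0.56 log units; beyond the scatter). The estimate for compound 4 in this assay is 4 nM, in the range 0.8 nM to 20 nM.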

Compound 4, half-maximal inhibitory concentration: 0.09 nM
For compound 4 the middle estimate is 44-fold (1.65 log units) above the measured one; the whole stated range lies above it.
By their numbers in this assay, from the lowest: compounds 4 and 2 (each within the scatter of the next); then compounds 1 and 3 (each within the scatter of the next).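

An aromatic ring is not needed on this double-bonded ring carbon for a low number in this assay: with the non-aromatic oxan-4-yl in place, the step from pyridin-4-yl stays small, a 1.6-fold lower number from compound 2 to compound 4 (0.19 log units; within the scatter), while the steps from the two substituted aromatic groups are large, a 12-fold lower number from compound 3 to compound 4 (1.09 log units; beyond the scatter) and an 11-fold lower number from compound 1 to compound 4 (1.05 log units; beyond the scatter). A nitrogen in this ring is not needed either, as oxan-4-yl has none and pyridin-4-yl has one, yet the two compounds stand within the scatter of each other, so the low numbers here span both an aromatic and a non-aromatic ring, with compounds 1 and 3 going against any simple split by aromaticity, as both carry aromatic groups and both have higher numbers than compound 4. No measurement in hand accounts for these shifts.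

Still open, from the compounds shown here alone, is how a cyclohexyl group, a piperidin-4-yl amine or an open alkyl chain would read on the same carbon, which would separate the part played by the oxygen of oxan-4-yl from that of the ring itself. Also open, going by these compounds, is whether a carboxylic acid or a methoxy group on the oxan-4-yl ring would raise the number, as methoxy does on the pyridine ring in a 7.9-fold higher number from compound 2 to compound 3 (0.90 log units; beyond the scatter).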